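Side-chain terminus variation on a shared core

The compounds below may be only part of what the source reports. "The series", "measured", "known", "first", "only" and "open" are said of these compounds alone.

Compound 2 `CCO/C(O)=C1\C(COCCNC(=O)NCC(N)=O)=NC(C)=C(C(=O)OC)C1c1ccccc1Cl` gives 20 nM in a functional assay (aorta) with Rattus norvegicus as the target; a lower number here means a stronger inhibitor, a higher number a weaker inhibitor. Among the three numbers it stands second highest; compound 1 `CCOC(=O)CNC(=O)NCCOCC1=C(C(=O)OCC)C(c2ccccc2Cl)/C(=C(\O)OC)C(C)=N1` gives 10 nM and compound 3 `CCO/C(O)=C1\C(COCCN(C)S(N)(=O)=O)=NC(C)=C(C(=O)OC)C1c1ccccc1Cl` gives 25.1 nM, and both of these lie within the scatter of compound 2. Compound 4 `CCO/C(O)=C1\C(COCCNC(C)C(N)=O)=NC(C)=C(C(=O)OC)C1c1ccccc1Cl` differs from compound 2 as follows: 1-carbamoylethyl in place of (carbamoylmethyl)carbamoyl on an amine nitrogen. Within the data shown here, the only measured step that alters the side chain is a 1.3-fold higher number from compound 2 to compound 3 (0.10 log units; within the scatter), which left the number unmoved beyond the scatter. With every number in the series this close, no step beyond the scatter is expected for compound 4 in this assay. The expected step is no change at the digits printed from compound 2 to compound 4 (within the scatter). Compound 4 is therefore estimated at 20 nM, with a range from 8 nM to 50 nM.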

Compound 4, half-maximal inhibitory concentration: 10 nM
Compound 4: the middle estimate sits 2.0-fold (0.30 log units) above what was measured; the range from low to high includes it.
By their numbers in this assay, from the lowest: compounds 1, 4, 2 and 3 (each within the scatter of the next, the first and the last beyond it).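

In this assay, 1-carbamoylethyl in place of (carbamoylmethyl)carbamoyl on the amine nitrogen gives a 2.0-fold lower number from compound 2 to compound 4 (0.30 log units; within the scatter) and stays within the scatter, so this position accepts the smaller of these two groups without a measurable change. (1-Carbamoylethyl)amino in place of methyl(sulfamoyl)amino gives a 2.5-fold lower number from compound 3 to compound 4 (0.40 log units; beyond the scatter), a modest step beyond the scatter that the earlier step on this side chain did not show. Nothing available explains either step.

Still open, from the compounds shown here alone, is how a carboxylic acid or a longer chain at this terminus would read in this assay, and whether a plain amine would hold the number seen for compound 4.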